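The compounds below may be only part of what the source reports. "The series", "measured", "known", "first", "only" and "open" are said of these compounds alone.

Measured compounds in an ADME assay on Vero cells (Chlorocebus sabaeus) for cytotoxicity, with a stated time of 7 days; on this read-out higher numbers stand for lower toxicity in this test and lower numbers for higher toxicity in this test:
Compound 1, `COc1ccc2[nH]c(C(=O)N3CC(=O)N(Cc4ccccc4)[C@@H](Cc4ccccn4)C3)cc2c1`: in this assay compound 1 gives > 30000 nM.
Compound 2, `COc1ccc2[nH]c(C(=O)N3CC(=O)N(Cc4ccccc4)[C@@H](COc4ccc(F)cc4)C3)cc2c1`: in this assay compound 2 gives 33200 nM.
Compound 3, `COc1ccc2[nH]c(C(=O)N3CC(=O)N(Cc4ccccc4)[C@@H](CN4CCC(C(C)C)CC4)C3)cc2c1`: in this assay compound 3 gives 3800 nM.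

The value of compound 1 is a limit of the assay, not a number (the limit of > 30000 nM in this assay, at which 1 of the 3 values shown sits). Within this assay compound 3 holds the lowest of the two numbers shown, the nearest being compound 2; the step from compound 1 to compound 2 is a step that the limit leaves unreadable from compound 1 to compound 2, whereas the steps of an at least 7.8-fold lower number from compound 1 to compound 3 (0.89 log units; beyond the scatter) and an 8.7-fold lower number from compound 2 to compound 3 (0.94 log units; beyond the scatter) both show that the 4-isopropylpiperidin-1-yl group of compound 3 goes with a clearly lower number than the pyridin-2-yl or 4-fluorophenoxy groups.

Compound 4, `COc1ccc2[nH]c(C(=O)N3CC(=O)N(Cc4ccccc4)[C@@H](CN4CCCc5ccccc54)C3)cc2c1`, differs from compound 3 by 1,2,3,4-tetrahydroquinolin-1-yl in place of 4-isopropylpiperidin-1-yl on a saturated chain carbon bound to a saturated ring carbon. For the measured compounds named here, no measured step exchanges one saturated nitrogen ring for another, so the direction rests only on compound 3 sitting apart from compounds 1 and 2 in this assay. The expectation is that compound 4 moves part of the way back toward the numbers of compounds 1 and 2, a step of a 2.6-fold higher number from compound 3 to compound 4 (0.42 log units; beyond the scatter) in this assay, with wide uncertainty. The estimate for compound 4 in this assay is 10000 nM, expected between 3000 nM and 35000 nM.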

Compound 4, half-maximal cytotoxic concentration: > 100000 nM
Compound 4 gave a limit, no number (the forecaster's own chance of this, stated with the estimate: 20%); middle value at least 10-fold (1.00 log units) away from the limit.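

In this assay the exchange at the saturated chain carbon bound to a saturated ring carbon gives an at least 26-fold higher number from compound 3 to compound 4 (1.42 log units; beyond the scatter), so a ring nitrogen bound at this carbon does not by itself go with the low number, since the 1,2,3,4-tetrahydroquinolin-1-yl and 4-isopropylpiperidin-1-yl groups both carry one. Measured against the 4-fluorophenoxy group, the 1,2,3,4-tetrahydroquinolin-1-yl group gives an at least 3.0-fold higher number from compound 2 to compound 4 (0.47 log units; beyond the scatter), which leaves compound 3 as the only one of the four shown with a clearly lower number in this assay. Compound 4 gives a limit of the assay, not a number: the limit of > 100000 nM in this assay, at which 1 of the 4 values shown sits.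

As far as these compounds go, compound 1 also gives a limit of the assay, and its step to compound 4 cannot be read: the limit of > 30000 nM in this assay, at which 1 of the 4 values shown sits. Whether the low number of compound 3 follows the isopropyl group or the piperidine ring stays open, and an unsubstituted piperidin-1-yl, a morpholin-4-yl or a primary amine on the same chain carbon would help separate the two.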